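The compounds below may be only part of what the source reports. "The series", "measured", "known", "first", "only" and "open" are said of these compounds alone.

Values in a functional assay on ECa-109 cells (Homo sapiens) for cytotoxicity, read by MTT assay, with a stated time of 72 h; a lower number here means a stronger inhibitor, a higher number a weaker inhibitor:
Compound 1 `CCC(C)=C1C(=O)N(c2ccc(Cl)cc2)N(c2ccc(Cl)cc2)C1=O`: 41100 nM
Compound 2 `O=C1C(=Cc2ccc(F)cc2)C(=O)N(c2ccc(Cl)cc2)N1c1ccc(Cl)cc1`: 35600 nM
Compound 3 `COc1cccc(C=C2C(=O)N(c3ccc(Cl)cc3)N(c3ccc(Cl)cc3)C2=O)c1O`: 39000 nM

At 35600 nM, compound 2 does not stand apart from the other two compounds, as all three values lie within the usual scatter of one another and no order can be drawn among them. Compound 4 `COc1cccc(C=C2C(=O)N(c3ccc(Cl)cc3)N(c3ccc(Cl)cc3)C2=O)c1` has not yet been measured. It differs from compound 2 by one change: 3-methoxyphenyl in place of 4-fluorophenyl on a double-bonded chain carbon bound to a double-bonded ring carbon. In words, 3-methoxyphenyl stands in place of 4-fluorophenyl on a double-bonded chain carbon bound to a double-bonded ring carbon.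

The closest measured evidence is the step to compound 3, which carries 2-hydroxy-3-methoxyphenyl at that place: a 1.1-fold higher number from compound 2 to compound 3 (0.04 log units; within the scatter). Among the compounds with values here, compound 4 lacks the hydroxy group of compound 3, and no measured pair shows what that group alone contributes. Compound 1, with a different chain at that place, gives 41100 nM, which also leaves it within the scatter of compound 2. On these three compounds, no shift beyond the scatter is expected, in either direction. The expected change is a 1.0-fold higher number from compound 2 to compound 4 (0.02 log units; within the scatter). For compound 4 the estimated value is 37000 nM, with an expected range from 20000 nM to 65000 nM.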

Compound 4, half-maximal inhibitory concentration: 29000 nM
Estimate against measurement, compound 4: 1.3-fold (0.11 log units) above; measured number inside the range.
By their numbers in this assay, from the lowest: compounds 4, 2, 3 and 1 (each within the scatter of the next).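

In this assay, within the data shown here, the exchange of 4-fluorophenyl for 3-methoxyphenyl on a double-bonded chain carbon bound to a double-bonded ring carbon gives a 1.2-fold lower number from compound 2 to compound 4 (0.09 log units; within the scatter), so this exchange, measured directly for the first time, does not separate the two compounds. Among these compounds, the same result supplies the pair that the earlier compounds lacked: hydrogen in place of hydroxy on an aromatic carbon gives a 1.3-fold lower number from compound 3 to compound 4 (0.13 log units; within the scatter), which is also within the scatter, and the hydroxy group of the 2-hydroxy-3-methoxyphenyl group therefore shows no separate contribution that can be read in this assay. Nothing at hand offers an explanation for how closely these compounds agree.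

The compounds shown leave open whether any group at this place can move the number beyond the scatter, for example an aromatic ring carrying an amine or a carboxylic acid, or a longer chain in place of the chain of compound 1. They also leave open what a change elsewhere in the shared core would do, as all four compounds differ only at this one place.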